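The source may report more compounds than this note shows. Statements on the series, on what has been measured and on what is new or still open speak of the compounds shown alone.

Measured compounds:
compound 1 `N#C/C(=C\c1cc2ccccc2[nH]1)C(=O)O` — 25.8%
compound 2 `N#C/C(=C\c1cc2ccccc2[nH]1)C(=O)NC1CCCCC1` — 45%

In a functional assay on the whole organism (strain CD1) for inhibition, with Mus musculus as the target, with stated times of 15 min and 20 min, at a dose of 10 mg/kg by the subcutaneous route (on this read-out higher numbers stand for more inhibition at the one dose given (going by the name of the read-out) and lower numbers for less inhibition), compound 2 gives 45% and stands highest of the two numbers; compound 1 gives 25.8%. For the measured compounds named here, the only measured step, a number 19.2 percentage points higher from compound 1 to compound 2 (beyond the scatter), is the one bearing on this part of the molecule, and it concerns the carbonyl substituent as a whole, not the group carried on the amide-type nitrogen.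

Compound 3 `N#C/C(=C\c1cc2ccccc2[nH]1)C(=O)Nc1ccccc1` keeps the amide and differs from compound 2 in one place: phenyl in place of cyclohexyl on an amide-type nitrogen. Going by the values given here, no measured pair exchanges one ring for another on the amide-type nitrogen, so no step tells how large such a change should be. Compound 3 is therefore expected to stay near compound 2, with a step of no change at the digits printed from compound 2 to compound 3 (within the scatter) that is estimated not to exceed the scatter, in either direction. The estimate for compound 3 in this assay is 45%, with a range from 25% to 65%.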

Compound 3, a percentage reported as inhibition, in the whole organism at one dose (the size of the read-out at that dose, not a potency): 52%
For compound 3 the middle estimate is 7 percentage points below the measured one, within the range that was stated.
By their numbers in this assay, from the lowest: compound 1; then compounds 2 and 3 (each within the scatter of the next).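

In this assay the exchange of the saturated ring for the aromatic one on the amide-type nitrogen reads as a number 7 percentage points higher from compound 2 to compound 3 (within the scatter), so at this dose the cyclohexyl and phenyl groups are not told apart at this position. The anilino amide also separates from the acid, with a number 26.2 percentage points higher from compound 1 to compound 3 (beyond the scatter), so the separation from hydroxy on the carbonyl carbon now holds for two amides rather than for cyclohexylamino alone, and neither of the two goes against it. Nothing on hand gives a reason for either step.

Still open, from the compounds shown here alone, is whether a ring on the nitrogen is needed at all, which a butyl chain or the plain unsubstituted amide would address. Also open, going by these compounds, are whether a methyl ester could stand in for the amide and whether a chloro group on the phenyl ring would move the number beyond the scatter.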